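The source may report more compounds than this note shows. Statements on the series, on what has been measured and on what is new or still open speak of the compounds shown alone.

Compound 1, `COc1cccc(-c2ccc(C(=O)N[C@H](C)CCCc3cccnc3)cc2)c1`, gives 20 nM in an assay (Canis lupus familiaris) for binding affinity to platelet-activating factor receptor (Homo sapiens), read by radioligand binding; on this read-out lower numbers stand for stronger inhibition and higher numbers for weaker inhibition. Compound 2, `COc1ccc(-c2ccc(C(=O)N[C@H](C)CCCc3cccnc3)cc2[N+](=O)[O-])cc1OC`, gives 200 nM in this assay. Compound 3, `COc1ccc(-c2ccc(C(=O)NCCCCc3cccnc3)cc2[N+](=O)[O-])cc1OC`, gives 200 nM in this assay.

Compound 4, `COc1cccc(-c2ccc(C(=O)NCCCCc3cccnc3)cc2)c1`, has not yet been measured in this assay. It differs from compound 1 by a single change, (hydrogen in place of methyl on a saturated chain carbon bound to an amide-type nitrogen and a saturated chain carbon). The same change has already been measured once: compound 3 differs from compound 2 by hydrogen in place of methyl on a saturated chain carbon bound to an amide-type nitrogen and a saturated chain carbon, and that step gave no change at the digits printed from compound 2 to compound 3 (within the scatter). The difference between the core of compound 1 and the core of compound 2 is not broken down here, so the two pairs share the change but not the surroundings. Because the earlier step of no change at the digits printed from compound 2 to compound 3 (within the scatter) stayed within the scatter, a similar outcome is expected here, no change at the digits printed from compound 1 to compound 4 (within the scatter). Compound 4 is therefore estimated at 20 nM, with a likely range from 8 nM to 50 nM.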

Compound 4, half-maximal inhibitory concentration: 280 nM
The estimate for compound 4 lay 14-fold (1.15 log units) below the measured number; measured number above the stated range.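

On the core of compound 1, hydrogen in place of methyl on a saturated chain carbon bound to an amide-type nitrogen and a saturated chain carbon gives a 14-fold higher number from compound 1 to compound 4 (1.15 log units; beyond the scatter) in this assay and so the methyl matters on this core. For the compounds shown here, with only two pairs, this does not show which difference between the two cores decides the outcome, nor why it does. It does show that the result of this change on one core cannot simply be carried over to the other: the same change on two cores in this assay, no change at the digits printed (within the scatter) from compound 2 to compound 3 and a 14-fold higher number (1.15 log units; beyond the scatter) from compound 1 to compound 4, 14-fold (1.15 log units) apart, beyond the scatter of two such steps

On these data alone, it remains open how the step would run on a core holding only part of the difference between compound 1 and compound 2. As far as these compounds go, what an ethyl group on that same chain carbon would do also stays open.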